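The compounds below may be only part of what the source reports. "The series", "measured", "known", "first", "only" and "open" are said of these compounds alone.

Measured compounds:
- compound 1, `O=S(=O)(NCCNCc1ccc(-c2ccccc2)cc1)c1cc(C(F)(F)F)cc(C(F)(F)F)c1`, in a functional assay on PANC-1 cells (Homo sapiens) for inhibition, read by MTT assay, with a stated time of 72 h (on this read-out higher numbers stand for weaker inhibition of growth and lower numbers for stronger inhibition of growth), gives 4200 nM
- compound 2, `O=S(=O)(NCCCCNCc1ccc(Br)cc1)c1cc(C(F)(F)F)cc(C(F)(F)F)c1`, gives 2200 nM
- compound 3, `O=S(=O)(NCCCNCc1ccc(Cl)c(Cl)c1)c1cc(C(F)(F)F)cc(C(F)(F)F)c1`, gives 5600 nM

On these numbers compound 3 stands highest, meaning the weakest inhibition of growth; its gap to compound 1 lies within the scatter, while its gap to compound 2 is beyond it. Compound 4, `O=S(=O)(NCCCNCc1ccc(C(F)(F)F)cc1)c1cc(C(F)(F)F)cc(C(F)(F)F)c1`, has not yet been measured. It differs from compound 3 in one place: 4-(trifluoromethyl)phenyl in place of 3,4-dichlorophenyl on a saturated chain carbon bound to an amine nitrogen. Going by the values given here, only one measured step touches the group on that benzylic carbon, the step from compound 2 to compound 3, which gave a 2.5-fold higher number from compound 2 to compound 3 (0.41 log units; beyond the scatter); but that step also changed the chain length, so it does not separate the effect of the aryl group alone. Among the compounds with values here, no measured pair shows a 4-(trifluoromethyl)phenyl group, so nothing here tells how it compares with 3,4-dichlorophenyl. The expectation is therefore a step from compound 3 to compound 4 no larger than the scatter, a 1.2-fold lower number from compound 3 to compound 4 (0.09 log units; within the scatter). Compound 4 is estimated at 4500 nM, likely between 1800 nM and 11000 nM.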

Compound 4, concentration for 50% growth inhibition: 3200 nM
The estimate for compound 4 lay 1.4-fold (0.15 log units) above the measured number; measured number inside the range.
By their numbers in this assay, from the lowest: compounds 2, 4, 1 and 3 (each within the scatter of the next, the first and the last beyond it).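

With the chain held the same, this assay shows a 1.8-fold lower number from compound 3 to compound 4 (0.24 log units; within the scatter) when 4-(trifluoromethyl)phenyl takes the place of 3,4-dichlorophenyl on a saturated chain carbon bound to an amine nitrogen. Going by these compounds alone, this is the first measured step that isolates the aryl group, and it shows that these two groups, one with two chlorine atoms and the other with three fluorine atoms, cannot be told apart on this read-out. No measurement at hand explains this result.

On these data alone, whether the 4-(trifluoromethyl)benzyl group would give a similar number on a longer chain remains open. So does the outcome with an unsubstituted phenyl ring, or with a nitrile or a carboxylic acid on that ring in place of trifluoromethyl.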